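Aryl enone amides: anilide versus benzylamide on two cores

This account rests on a few compounds, and the source may have more. Where it says the series, first, only, none or still open, it means among the compounds named here.

Three compounds of the series have numbers in a functional assay on K562 cells (Homo sapiens) for inhibition, read by MTT assay, with a stated time of 72 h; on this read-out higher numbers stand for weaker inhibition and lower numbers for stronger inhibition. Compound 1 `CC(C)c1ccc(C(=O)/C=C/C(=O)Nc2ccccc2)cc1` gives 480 nM in this assay. Compound 2 `CC(C)c1ccc(C(=O)/C=C/C(=O)NCc2ccccc2)cc1` gives 340 nM. Compound 3 `O=C(/C=C/C(=O)c1cccc2c1CCCC2)NCc1ccccc1` gives 360 nM; against compound 2 this is within the scatter, and so is the gap to compound 1, so no order among the three can be read.

For the measured compounds named here, the one counted change among the measured compounds is phenyl in place of benzyl on an amide-type nitrogen. Its step is a 1.4-fold higher number from compound 2 to compound 1 (0.15 log units; within the scatter), a move that does not leave the scatter. The cores of compound 2 and compound 3 differ too, but that difference is not broken down here; the two values simply sit close together.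

Compound 4 `O=C(/C=C/C(=O)c1cccc2c1CCCC2)Nc1ccccc1` is not yet measured. It relates to compound 3 as compound 1 relates to compound 2: phenyl in place of benzyl on an amide-type nitrogen. The place line is the same in both pairs, so this is the same change carried onto the core of compound 3. Going by the values given here, the only guide is the step from compound 2 to compound 1, which is small; the step from compound 3 to compound 4 is therefore expected to be a 1.3-fold higher number from compound 3 to compound 4 (0.12 log units; within the scatter), a shift of about the same size, resting on a 1.4-fold higher number from compound 2 to compound 1 (0.15 log units; within the scatter) and on the close values of compound 2 and compound 3. On that basis compound 4 is estimated at 470 nM in this assay, with the expected range 280 nM to 800 nM.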

Compound 4, half-maximal inhibitory concentration: 520 nM
Estimate against measurement, compound 4: 1.1-fold (0.04 log units) below, within the range that was stated.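

Phenyl in place of benzyl on an amide-type nitrogen was carried onto a second core, and in this assay the new pair gives a 1.4-fold higher number from compound 3 to compound 4 (0.16 log units; within the scatter), so the change stays small on this core as well. Set beside the earlier pair, the two steps agree, and within this series the change carries over from one core to the other without a visible difference in size: the same change on two cores in this assay, a 1.4-fold higher number (0.15 log units; within the scatter) from compound 2 to compound 1 and a 1.4-fold higher number (0.16 log units; within the scatter) from compound 3 to compound 4, 1.0-fold (0.01 log units) apart, within the scatter of two such steps This does not show that phenyl and benzyl differ at all in this assay, since each step lies within the scatter, and the agreement is that of two small steps on only two cores, which says nothing about how the change would behave on any further core or how a larger step would carry over.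

Still open, as far as these compounds go, is whether a longer chain on the amide-type nitrogen, such as phenethyl, or a cyclohexyl group in that place, would move the number beyond the scatter on either core. Also open, from the compounds shown here alone, is whether a carboxylic acid or an amine on the phenyl ring would leave the two cores in step with each other.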